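Compound 3 to compound 4: trifluoromethyl replacement

The compounds below may be only part of what the source reports. "The series", "measured", "known", "first", "only" and "open" are said of these compounds alone.

Measured so far (values from an ADME assay on S9 fraction from liver (Homo sapiens) for metabolic stability, with a stated time of 1 h; a lower number here means that less of the compound is left, a higher number that more of the compound is left)
- compound 1 `N#Cc1cnc(NCc2cnccc2C(F)(F)F)cc1N[C@H]1C[C@@H](O)C1` gives 90%
- compound 2 `N#Cc1cnc(NCc2ccccc2C(F)(F)F)cc1N[C@H]1C[C@H](C(N)=O)C1` gives 68%
- compound 3 `N#Cc1cnc(NCc2cncnc2C(F)(F)F)cc1N[C@H]1CC[C@@H](O)CC1` gives 76%

Compound 3 lies within the scatter of compound 2, while compound 1 stands higher than compound 3, beyond the scatter. Compound 4 `CC(C)(F)c1ncncc1CNc1cc(N[C@H]2CC[C@@H](O)CC2)c(C#N)cn1` is not yet measured. It departs from compound 3 in one place: 1-fluoro-1-methylethyl in place of trifluoromethyl on an aromatic carbon with 1-fluoro-1-methylethyl in place of trifluoromethyl on an aromatic carbon. Within the data shown here, the measured compounds differ from one another in more than one place, so no measured step shows the effect of this replacement alone. A small fall in this assay is expected, close to the usual scatter, and a result within the scatter would not be surprising. Among the measured compounds shown here, the estimate starts from compound 3 at 76% as its anchor and is a judgement with no direct precedent. The expected step is a number 8 percentage points lower from compound 3 to compound 4 (within the scatter) as an estimate only. For compound 4 the estimate is 68% with an expected range from 48% to 85% until a measurement is available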

Compound 4, percent of the compound remaining: 89%
The estimate for compound 4 lay 21 percentage points below the measured number, outside the stated range (above it).
By their numbers in this assay, from the lowest: compounds 2 and 3 (each within the scatter of the next); then compounds 4 and 1 (each within the scatter of the next).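

In this assay, among these compounds, 1-fluoro-1-methylethyl in place of trifluoromethyl, on the aromatic carbon next to the ring nitrogen, gives the first step that isolates one change: a number 13 percentage points higher from compound 3 to compound 4 (beyond the scatter) in the amount left after the stated time. At this position, trifluoromethyl is therefore not needed to keep the compound from being lost in this assay, and a group with three carbons and one fluorine serves at least as well as one with one carbon and three fluorines. No available measurement bears on what lies behind this step.

Going by these compounds, whether a difluoromethyl group, a cyclopropyl group or an amine on this aromatic carbon would hold the number remains open. On these data alone, it is also open whether the same replacement would carry over to compound 1 and compound 2, which still bear trifluoromethyl.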